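The source may hold more compounds than are shown below. What is called first, only, known or untested is meant among the compounds shown, and "the series" means these compounds.

Measured compounds:
compound 1 `C=CCn1c(SCC(=O)Nc2ccc(C(C)=O)cc2)nnc1-c1ccc(OC)c(OC)c1` with 57%
compound 2 `C=CCn1c(SCC(=O)Nc2ccc(/C(C)=N/O)cc2)nnc1-c1ccc(OC)c(OC)c1` with 56%
compound 3 `CCn1c(SCC(=O)Nc2ccc(/C(C)=N/O)cc2)nnc1-c1ccccc1` with 57%

All three values come from a functional assay on the whole organism (strain albino) for inhibition, with Rattus norvegicus as the target, read by paw edema, with stated times of 30 min and 2 h, at a dose of 0.28 mmol/kg by the oral route; on this read-out higher numbers stand for more inhibition at the one dose given (going by the name of the read-out) and lower numbers for less inhibition. Compound 1 and compound 2 share a core and differ in one place: a group of 3 heavy atoms (2 carbon, 1 oxygen; no ring) in place of a group of 4 heavy atoms (2 carbon, 1 nitrogen, 1 oxygen; no ring), on an aromatic carbon. This change gave a number 1 percentage points higher from compound 2 to compound 1 (within the scatter), so the two values lie within the usual scatter of one another. Compound 3 rests on a different core; how that core differs from the core of compound 2 is not broken down here. Its value sits level with compound 1 at the digits given, and the two of them, together with compound 2, fall within the scatter of each other, so no order among the three can be read from these numbers.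

Compound 4 `CCn1c(SCC(=O)Nc2ccc(C(C)=O)cc2)nnc1-c1ccccc1` has not been measured. It stands to compound 3 as compound 1 stands to compound 2: a group of 3 heavy atoms (2 carbon, 1 oxygen; no ring) in place of a group of 4 heavy atoms (2 carbon, 1 nitrogen, 1 oxygen; no ring), on an aromatic carbon. The place is described in the same words for both pairs, so this is the same change on a different core. Because compound 1 against compound 2 showed a number 1 percentage points higher from compound 2 to compound 1 (within the scatter), the step from compound 3 to compound 4 is expected to be small, about a number 1 percentage points higher from compound 3 to compound 4 (within the scatter). Compound 4 is therefore estimated at 58%, with a likely range from 50% to 66%.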

Compound 4, a percentage reported as inhibition, in the whole organism at one dose (the size of the read-out at that dose, not a potency): 53%
Compound 4: middle estimate off by 5 percentage points, on the high side; the range from low to high includes it.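

In this assay, the exchange that brings in acetyl gave a number 4 percentage points lower from compound 3 to compound 4 (within the scatter), and set beside the same exchange on the other core, the two steps do not differ beyond what repeated measurements would allow: the same change on two cores in this assay, a number 1 percentage points higher (within the scatter) from compound 2 to compound 1 and a number 4 percentage points lower (within the scatter) from compound 3 to compound 4, 5 percentage points apart, within the scatter of two such steps

On the evidence of these two pairs, the change carries from one core to the other in the sense that neither core shows a step beyond the scatter. Within the data shown here, this does not show that the change has no effect, nor that its effect is the same on both cores, since a small effect or a small difference between the cores would be hidden within the scatter, and only two cores at a single dose are compared.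

The compounds shown leave open whether a different group on this aromatic carbon, such as an amine, a carboxylic acid or a longer chain, would move the inhibition of paw edema beyond the scatter. They also leave open whether the two pairs would stay alike on further cores.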